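Working notes: replacing the aryl group on compound 1

A few compounds are considered here, and "the series" means these few. Any claim that something is new, unique, unknown or untested is made for them only; others in the source may bear on it.

Measured in a toxicity assay on HUVEC cells (Homo sapiens) for inhibition; on this read-out higher numbers stand for weaker inhibition of growth and lower numbers for stronger inhibition of growth:
- compound 1 `Cc1ccc(C)c(N2CCN(C(=O)c3oc(C)nc3-c3ccccc3)CC2)c1` (1.73 ug/mL)
- compound 2 `Cc1nc(-c2cccc(F)c2)c(C(=O)N2CCN(c3cc(Cl)cc(Cl)c3)CC2)o1` (0.134 ug/mL)

Compound 1 (1.73 ug/mL) holds the higher of the two numbers in this assay, so it shows the weaker inhibition of growth. Compound 2 (0.134 ug/mL) lies lower, and the gap between them is beyond the scatter.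

The next compound to be measured is compound 3 `Cc1nc(-c2ccccc2)c(C(=O)N2CCN(c3cccc(C#N)c3)CC2)o1`. It keeps the core of compound 1 and carries 3-cyanophenyl in place of 2,5-dimethylphenyl on an amine nitrogen in a ring.

Among the compounds with values here, no measured pair differs in one place only, so the size of this step in this assay has no direct guide. No change beyond the scatter is expected, and no direction is favoured with any confidence. The low number of compound 2 (0.134 ug/mL) shows that values well under that of compound 1 occur in the series, so the range is kept wide. The expected change is small (a 1.2-fold lower number from compound 1 to compound 3 (0.06 log units; within the scatter)). For compound 3 the estimated value is 1.5 ug/mL (expected range 0.4 ug/mL to 6 ug/mL).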

Compound 3, concentration for 50% growth inhibition: 2.52 ug/mL
Compound 3: the middle estimate sits 1.7-fold (0.23 log units) below what was measured; measured number inside the range.
By their numbers in this assay, from the lowest: compound 2; then compounds 1 and 3 (each within the scatter of the next).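

In this assay, within the data shown here, the step of a 1.5-fold higher number from compound 1 to compound 3 (0.16 log units; within the scatter) gives the first direct reading at this position, the aryl group on the amine nitrogen in the six-membered ring. With the rest of the structure unchanged, 3-cyanophenyl and 2,5-dimethylphenyl cannot be told apart on this read-out, even though the exchange replaces two methyl groups with a nitrile, adds a hydrogen-bond acceptor and keeps the heavy-atom count the same. No independent data are available to explain this result.

Compound 2 differs from compound 1 in more than one place, so the value of compound 2 (0.134 ug/mL) cannot be assigned to the aryl group on the ring nitrogen alone, and the contribution of this position to that low number remains unresolved. Going by these compounds, it also remains open whether this tolerance extends to a phenyl ring bearing an amine or a carboxylic acid, or to a pyridine ring, in the same place on an otherwise unchanged structure.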